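Lipophilicity notes: compound 4 from compound 1

This account rests on a few compounds, and the source may have more. Where it says the series, first, only, none or still open, it means among the compounds named here.

Measured in a physicochemical assay for lipophilicity, read by HPLC, at pH 7.5; a higher number here means a more lipophilic compound, a lower number a more polar compound:
compound 1, `CCCCC(Nc1c(C#N)c(-c2ccc(-c3ccccc3OCC)cc2)nc2cnccc12)C(N)=O`: 3.6
compound 2, `CC(C)(CC(N)=O)c1c(C#N)c(-c2ccc(Br)cc2)nc2cnccc12`: 2.1
compound 3, `CC[C@@H](Nc1c(C#N)c(-c2ccc(-c3cccc(Cl)c3F)cc2)nc2cnccc12)C(N)=O`: 3.1

Compound 1 gives the highest of the three numbers. Compound 3 lies nearest to it, lower by a margin beyond the scatter; compound 2 lies furthest, lower by a wider margin, also beyond the scatter. Going by the values given here, no two of these three differ in only one place, so no measured single step exists in this assay.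

Compound 4, `CCOc1ccccc1-c1ccc(-c2nc3cnccc3c(NC(C)C(=O)O)c2C#N)cc1`, awaits measurement. It differs from compound 1 in one place: 1-carboxyethyl in place of 1-carbamoylpentyl on a nitrogen on an aromatic ring

Among the compounds with values here, no measured pair shows a change of this kind, so the expectation rests on the change itself. Compound 4 is expected at 1.3, within 0.6 to 2. The expected step of a number 2.30 log units lower from compound 1 to compound 4 (beyond the scatter) is a fall well beyond the scatter.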

Compound 4, distribution coefficient: 2.1
Beside the measured number, compound 4's estimate is 0.80 log units below it; measured number above the stated range.
By their numbers in this assay, from the lowest: compounds 2 and 4 (each within the scatter of the next); then compound 3; then compound 1.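

In this assay, going by these compounds alone, the group on a nitrogen on an aromatic ring carries real weight: 1-carboxyethyl in place of 1-carbamoylpentyl gives a number 1.50 log units lower from compound 1 to compound 4 (beyond the scatter) as the first single-place step. The earlier compounds shown here differ in several places and could not isolate this position. No measured evidence bears on the origin of this step.

On these data alone, this change alters chain length and end group together, so the share of each stays open. A 1-carboxypentyl group or a 1-carbamoylethyl group on the same nitrogen would separate the two.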